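A few compounds are considered here, and "the series" means these few. Any claim that something is new, unique, unknown or untested is made for them only; others in the source may bear on it.

Compound 1 `COc1ccccc1Nc1nc(-c2cccc(F)c2)nc2ccc(F)cc12` gives > 50000 nM in a functional assay on HT29-AK cells (Homo sapiens) for cytotoxicity, read by MTT assay, with a stated time of 48 h (on this read-out higher numbers stand for weaker inhibition and lower numbers for stronger inhibition), which is a limit of the assay and not a number. Compound 2 `Fc1cccc(Nc2nc(-c3cccc(F)c3)nc3ccc(F)cc23)c1` gives > 50000 nM, again a limit. Compound 3 `Fc1cccc(-c2nc(Nc3ccc(Cl)cc3)c3cc(F)ccc3n2)c1` gives 40300 nM.

Compound 1 thus stands at the limit of > 50000 nM in this assay, at which 2 of the 3 values shown sit. The change to compound 4 `Oc1cccc(Nc2nc(-c3cccc(F)c3)nc3ccc(F)cc23)c1` is 3-hydroxyphenyl in place of 2-methoxyphenyl on a nitrogen on an aromatic ring. Within the data shown here, the steps that bear on it are those from compound 1 that alter the same phenyl group on the same nitrogen: a step that the two limits leave unreadable from compound 1 to compound 2 and an at least 1.2-fold lower number from compound 1 to compound 3 (0.09 log units; that floor lies within the scatter). Neither shows a step beyond the scatter, and an at least 1.2-fold lower number from compound 2 to compound 3 (0.09 log units; that floor lies within the scatter) is also within it. Among the measured compounds shown here, no measured step therefore supports a change beyond the scatter in this assay for compound 4, and a limit is again likely. Compound 4 is estimated at 50000 nM, from 25000 nM to 100000 nM. The step of a number no higher from compound 1 to compound 4 (the limit leaves the size open) that this estimate means is expected to stay within the scatter.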

Compound 4, half-maximal inhibitory concentration: > 50000 nM
Compound 4 gave a limit, no number; the forecaster's own chance of this, stated with the estimate: 65%; the middle value sits exactly at the limit.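

In this assay compound 4 with 3-hydroxyphenyl on the nitrogen stays at a limit of the assay, so this group joins the 2-methoxyphenyl of compound 1 and the 3-fluorophenyl of compound 2 without yielding a number: the limit of > 50000 nM in this assay, at which 3 of the 4 values shown sit. The steps from compound 1 and from compound 2 to compound 4 cannot be read. Among these compounds, the one readable step is an at least 1.2-fold higher number from compound 3 to compound 4 (0.09 log units; that floor lies within the scatter) and so does not set 3-hydroxyphenyl apart from 4-chlorophenyl.

Still open, going by these compounds, is whether an amine or a carboxylic acid on this phenyl ring would give a number beyond the scatter.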